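A Dihydroxyphenyl Variant of Compound 1, Awaiting Measurement

A few compounds are considered here, and "the series" means these few. Any claim that something is new, unique, unknown or untested is made for them only; others in the source may bear on it.

Compound 1 `COc1cc(OC)c(OC)cc1/C=C/C(=O)c1cc(Cl)ccc1O`: 2.32 ug/mL
Compound 2 `COc1cc(OC)c(OC)cc1/C=C/C(=O)c1cc(Cc2ccccc2)cc(Cc2ccccc2)c1`: 2.09 ug/mL
Compound 3 `COc1cc(OC)c(-c2cc(=O)c3cc(O)ccc3o2)cc1OC`: 2.14 ug/mL

These three compounds were measured in a functional assay, read by Griess assay, with a stated time of 2.5 h; a higher number here means a weaker inhibitor, a lower number a stronger inhibitor. On the numbers shown, compound 1 has the highest of the three, but the other two lie within the usual scatter of it: compound 3 gives 2.14 ug/mL and compound 2 gives 2.09 ug/mL. The three therefore cannot be told apart on this evidence, and no pattern among them can be drawn.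

Within the data shown here, none of the measured compounds differ from one another in a single place, so no step of known size exists to lean on. The unmeasured compound 4 `COc1cc(OC)c(OC)cc1/C=C/C(=O)c1ccc(O)cc1O` differs from compound 1 in one place:

2,4-dihydroxyphenyl in place of 5-chloro-2-hydroxyphenyl on a carbonyl carbon

Among the measured compounds shown here, with no comparable step in this assay, the expectation rests on the closeness of the three measured values and on the modest nature of the change. The expected step is a 1.3-fold higher number from compound 1 to compound 4 (0.11 log units; within the scatter), small, and if anything toward a higher number, but not clearly beyond the scatter. Compound 4 is estimated to give 3 ug/mL in this assay, within a range from 1.2 ug/mL to 8 ug/mL.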

Compound 4, half-maximal inhibitory concentration: 2.76 ug/mL
Compound 4: the middle estimate sits 1.1-fold (0.04 log units) above what was measured; the measured number falls inside the stated range.
By their numbers in this assay, from the lowest: compounds 2, 3, 1 and 4 (each within the scatter of the next).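

In this assay, among these compounds, the pair of compound 1 and compound 4 gives the first step at a single position, the aryl group on a carbonyl carbon whose other neighbour is a double-bonded chain carbon, and it reads a 1.2-fold higher number from compound 1 to compound 4 (0.08 log units; within the scatter), which no earlier comparison could supply. Exchanging 5-chloro-2-hydroxyphenyl for 2,4-dihydroxyphenyl removes the chlorine and brings in more hydrogen-bond donors and acceptors, yet the two compounds cannot be told apart here, so this change at this position has no effect that can be read beyond the scatter. No measurement is available that could explain this outcome.

Among the compounds shown here, the single step joins the loss of the chlorine and the gain of the second hydroxyl, so a plain 2-hydroxyphenyl group at the same place would be needed to tell their contributions apart. It also remains open whether a group of a different kind on this carbonyl carbon, such as an aminophenyl or a carboxyphenyl, would give a step beyond the scatter, since all four compounds shown lie within the scatter of their neighbours in the order of their numbers.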